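This account rests on a few compounds, and the source may have more. Where it says the series, first, only, none or still open, it means among the compounds named here.

Of the compounds shown here, two with a shared core have been tested in a functional assay on HepG2 cells (Homo sapiens) for cytotoxicity, read by MTT assay, with a stated time of 48 h; on this read-out higher numbers stand for weaker inhibition and lower numbers for stronger inhibition. Compound 1 `O=C(CSc1nnc(-c2ccncc2)o1)N/N=C/c1ccccc1[N+](=O)[O-]` gives 24700 nM in this assay. Going by the values given here, compound 2 `O=C(CSc1nnc(-c2ccncc2)o1)N/N=C/c1cc(Cl)ccc1O` gives 3970 nM in this assay, the lowest of the two numbers; the only measured step, a 6.2-fold lower number from compound 1 to compound 2 (0.79 log units; beyond the scatter), separates it from compound 1. Compound 3 `O=C(CSc1nnc(-c2ccncc2)o1)N/N=C/c1cc(Cl)cc(Cl)c1O` is not yet measured. It differs from compound 2 by chloro in place of hydrogen on an aromatic carbon. Among the compounds with values here, no measured step covers this kind of change: the one known step swapped a whole substituted ring, so it offers only a loose guide. Adding one chlorine to a ring that already carries a chloro and a hydroxy group is a small alteration, and a step of no more than modest size is expected, with a slight lean toward a lower number. For compound 3 the expected step is a 1.6-fold lower number from compound 2 to compound 3 (0.20 log units; within the scatter). Compound 3 is therefore estimated at 2500 nM, within a range from 1000 nM to 8000 nM.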

Compound 3, half-maximal inhibitory concentration: 3260 nM
Compound 3: the middle estimate sits 1.3-fold (0.12 log units) below what was measured; the measured number falls inside the stated range.
By their numbers in this assay, from the lowest: compounds 3 and 2 (each within the scatter of the next); then compound 1.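

In this assay, a chloro in place of hydrogen on the aromatic carbon ortho to the hydroxy group leaves the number within the scatter, with a 1.2-fold lower number from compound 2 to compound 3 (0.09 log units; within the scatter), so compound 2 and compound 3 cannot be told apart here. Compound 3 also stands clearly apart from the 2-nitrophenyl ring of compound 1, with a 7.6-fold lower number from compound 1 to compound 3 (0.88 log units; beyond the scatter), so the 3,5-dichloro-2-hydroxyphenyl ring keeps the separation already seen with the 5-chloro-2-hydroxyphenyl ring. No supporting measurement is available to explain this result.

As far as these compounds go, whether a methoxy group, an amine or a longer chain on this same carbon would move the number beyond the scatter remains open. Also open, from the compounds shown here alone, is whether the hydroxy group matters, which would take a close analogue carrying a methoxy group in its place.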